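The source may report more compounds than this note shows. Statements on the series, on what has been measured and on what is new or still open speak of the compounds shown alone.

Compound 1 `COCCCNc1nccc(-c2c(C)[nH]c3ccccc23)n1` gives 1500 nM in an assay on isolated protein for inhibition of interferon-induced, double-stranded RNA-activated protein kinase (Homo sapiens), read by luminescence, with a stated time of 10 min; a higher number here means a weaker inhibitor, a lower number a stronger inhibitor. Of the two compounds measured there it has the lowest number; the nearest is compound 2 `COC(=O)c1ccc2c(-c3ccnc(NCCO)n3)c[nH]c2c1`, which in this assay gives 9000 nM, a gap that lies beyond the usual scatter. Compound 2 shares the core of compound 1 but differs from it in more than one place, so no single step can be read from that pair.

Compound 3 `Cc1[nH]c2ccccc2c1-c1ccnc(Nc2cccnc2)n1` has not yet been measured. It differs from compound 1 in one place: pyridin-3-yl in place of 3-methoxypropyl on a nitrogen on an aromatic ring. No measured step in this assay corresponds to that change, so what follows rests on the two numbers shown and on the change itself. For compound 3 the step from compound 1 is expected to run toward a lower number, of a modest size that may reach beyond the scatter a 2.5-fold lower number from compound 1 to compound 3 (0.40 log units; beyond the scatter). On that basis compound 3 is estimated to give about 600 nM in this assay, with a likely range from 120 nM to 3000 nM.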

Compound 3, half-maximal inhibitory concentration: 100 nM
The estimate for compound 3 lay 6.0-fold (0.78 log units) above the measured number; the whole stated range lies above it.
By their numbers in this assay, from the lowest: compound 3; then compound 1; then compound 2.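

In this assay, among these compounds, the change on the nitrogen on an aromatic ring provides the first step that can be read: a 15-fold lower number from compound 1 to compound 3 (1.18 log units; beyond the scatter), a large step that lies well beyond the scatter. It shows that the number is sensitive to the group at this place, as replacing the open chain of 3-methoxypropyl with the aromatic ring of pyridin-3-yl lowers it markedly, even though the two groups carry the same counts of hydrogen-bond donors and acceptors. No measurement on hand explains the size of this step.

The compounds shown leave open whether the lower number depends on the aromatic ring itself or on its ring nitrogen, a question that phenyl, or pyridin-4-yl with the ring nitrogen placed differently, would help to answer. Among the compounds shown here, compound 2 differs from both other compounds in more than one place, so no step to it can be read, and it also remains open whether a saturated ring such as piperidin-4-yl would give a number as low as that of compound 3.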